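A Bromophenyl Swap on Compound 3

A few compounds are considered here, and "the series" means these few. Any claim that something is new, unique, unknown or untested is made for them only; others in the source may bear on it.

In a functional assay for inhibition, with Homo sapiens as the target (on this read-out higher numbers stand for weaker binding and lower numbers for tighter binding), compound 1 (`O=C(O)CC/C=C\CC1COC(c2ccccc2Cl)OC1c1cccnc1`) gives 759 nM and compound 2 (`O=C(O)CC/C=C\CC1COC(c2ccsc2)OC1c1cccnc1`) gives 1580 nM as its reading. Compound 3 (`CC(C)(C)c1ccc(OC(C)(C)C2OCC(C/C=C\CCC(=O)O)C(c3cccnc3)O2)cc1`) gives 1910 nM as its reading, which lies within the usual scatter of compound 2 and beyond the scatter above compound 1.

Compound 4 (`CC(C)(Oc1ccccc1Br)C1OCC(C/C=C\CCC(=O)O)C(c2cccnc2)O1`) differs from compound 3 in one group, with 2-bromophenyl in place of 4-(tert-butyl)phenyl on an oxygen on a saturated carbon.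

Among the measured compounds shown here, the only measured single change, a 2.1-fold higher number from compound 1 to compound 2 (0.32 log units; beyond the scatter) for thiophen-3-yl in place of 2-chlorophenyl on a saturated ring carbon, is modest and sits at a different place, so it guides size only roughly. The slight lean toward a lower number rests on compound 1, which carries 2-chlorophenyl and reads 759 nM as its value. The expected step, a 1.6-fold lower number from compound 3 to compound 4 (0.20 log units; within the scatter) in this estimate, is small and not clearly beyond the scatter. For compound 4 the estimated value is 1200 nM with a range from 450 nM to 3200 nM expected around it.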

Compound 4, dissociation constant: 63.1 nM
Compound 4: middle estimate off by 19-fold (1.28 log units), on the high side; the whole stated range lies above it.
By their numbers in this assay, from the lowest: compound 4; then compound 1; then compounds 2 and 3 (each within the scatter of the next).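

Within this assay, the group on this oxygen turns out to carry much more weight than the only earlier step, a 2.1-fold higher number from compound 1 to compound 2 (0.32 log units; beyond the scatter), which sits at a different place, could show. Here the change to 2-bromophenyl from 4-(tert-butyl)phenyl gives a 30-fold lower number from compound 3 to compound 4 (1.48 log units; beyond the scatter), a large step. The entering group has fewer heavy atoms than the leaving group and brings in bromine, while both groups have one six-membered aromatic ring of carbon only, no hydrogen-bond donors or acceptors and no net charge; nothing in the data shown explains the size of the step.

The change removes the tert-butyl group and adds the bromine in one move, so the two contributions cannot be told apart. A plain phenyl on this oxygen, or a fluorine or methoxy group in place of the bromine, would be needed to separate them.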